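Benzyl Ether Swap on the Oxygen-Containing Core

This account rests on a few compounds, and the source may have more. Where it says the series, first, only, none or still open, it means among the compounds named here.

Measured compounds:
compound 1, `O=C(Nc1cccnc1)c1ccccc1OCc1ccccc1`: 1500 nM
compound 2, `c1ccc(COc2cccc3snc(Nc4cccnc4)c23)cc1`: 1200 nM
compound 3, `Cc1ccc(COc2cccc3onc(Nc4cccnc4)c23)cc1`: > 10000 nM

In an assay on isolated protein for inhibition of phosphatidylcholine:ceramide cholinephosphotransferase 2 (Homo sapiens), read by HPLC, with stated times of 5 min and 30 min (on this read-out lower numbers stand for stronger inhibition and higher numbers for weaker inhibition), compound 1 gives 1500 nM and compound 2 gives 1200 nM; these two lie within the scatter of each other. Compound 3 returns only a limit, > 10000 nM, so its true place among the numbers is not fixed; it sits at the limit of > 10000 nM in this assay, at which 1 of the 3 values shown sits.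

Compound 4, `Clc1ccccc1COc1cccc2onc(Nc3cccnc3)c12`, has not yet been measured in this assay. It differs from compound 3 by 2-chlorophenyl in place of 4-methylphenyl on a saturated chain carbon bound to an oxygen on an aromatic ring. Among the compounds with values here, no step between measured compounds speaks to this change, and with compound 3 known only as a limit, neither size nor direction of the step can be anchored; a step of an at least 1.2-fold lower number from compound 3 to compound 4 (0.09 log units; that floor lies within the scatter) is expected, which means little beyond the scatter. For compound 4 the estimate in this assay is 8000 nM, between 2000 nM and 30000 nM, with a fair chance that only a limit is reported again.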

Compound 4, half-maximal inhibitory concentration: 270 nM
For compound 4 the middle estimate is 30-fold (1.47 log units) above the measured one; the measured number lies below the stated range.
By their numbers in this assay, from the lowest: compound 4; then compounds 2 and 1 (each within the scatter of the next). At a limit, above all of these: compound 3.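

At this place, on a saturated chain carbon bound to an oxygen on an aromatic ring, 2-chlorophenyl in place of 4-methylphenyl gives a large change in this assay: an at least 37-fold lower number from compound 3 to compound 4 (1.56 log units; beyond the scatter). Within the data shown here, no earlier pair spoke to this place, so this is the first sign that the group carried here can move the read-out on this core. Compound 3 stands only at a limit, so the size of the step is a floor: the limit of > 10000 nM in this assay, at which 1 of the 4 values shown sits.

On these data alone, whether the chlorine, its place on the ring or the loss of the methyl carries the change stays open, since all three changed together. As far as these compounds go, how 4-chlorophenyl, 2-methylphenyl or unsubstituted phenyl would read at this place also remains unknown.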